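This account rests on a few compounds, and the source may have more. Where it says the series, first, only, none or still open, it means among the compounds named here.

Measured compounds in an assay on CHO cells for inhibition of 3-oxo-5-alpha-steroid 4-dehydrogenase 2 (Homo sapiens); a higher number here means a weaker inhibitor, a lower number a stronger inhibitor:

- compound 1, `O=C(O)c1ccc(C(=O)c2ccc(C(=O)c3ccc(O)cc3)cc2)cc1`: 22 nM
- compound 2, `O=C(O)c1ccc(C(=O)c2ccc(C(=O)c3ccc([N+](=O)[O-])cc3)cc2)cc1`: 100 nM
- compound 3, `O=C(O)c1ccc(C(=O)c2ccc(-c3ccc(Cl)cc3Cl)cc2)cc1`: 85 nM

Compound 3 stands in the upper part of these three numbers. Compound 3 and compound 2 lie within the scatter of each other, so no order between them can be read. Compound 3 gives a clearly higher number than compound 1, a gap beyond the scatter.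

Compound 4, `O=C(O)c1ccc(C(=O)c2ccc(C(=O)C3CCCCC3)cc2)cc1`, differs from compound 3 at one spot: cyclohexylcarbonyl in place of 2,4-dichlorophenyl on an aromatic carbon. For the measured compounds named here, the only single-site step among the measured compounds is a 4.5-fold higher number from compound 1 to compound 2 (0.66 log units; beyond the scatter), a swap of one small substituent at the far end of the molecule. It shows that a change at that end can move the number, but it does not match the present change, which replaces the whole terminal group with a cyclohexylcarbonyl. Going by the values given here, no measured step tells what a non-aromatic ring at this end does. The expectation for compound 4 is therefore a step of a 1.4-fold lower number from compound 3 to compound 4 (0.15 log units; within the scatter), essentially within the scatter, with wide uncertainty. Compound 4 is estimated at 60 nM, ranging from 12 nM to 300 nM.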

Compound 4, inhibition constant: 30 nM
Compound 4: middle estimate off by 2.0-fold (0.30 log units), on the high side, within the range that was stated.
By their numbers in this assay, from the lowest: compounds 1 and 4 (each within the scatter of the next); then compounds 3 and 2 (each within the scatter of the next).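

In this assay, the terminal ring at this position need not be aromatic: replacing 2,4-dichlorophenyl with cyclohexylcarbonyl gives a clear gain (a 2.8-fold lower number from compound 3 to compound 4 (0.45 log units; beyond the scatter)). The cyclohexyl group on the carbonyl carbon also improves on 4-nitrophenyl (a 3.3-fold lower number from compound 2 to compound 4 (0.52 log units; beyond the scatter)), whereas its difference from 4-hydroxyphenyl stays within the scatter (a 1.4-fold higher number from compound 1 to compound 4 (0.13 log units; within the scatter)), so no order can be read there. No measurement shown here offers an explanation for these steps.

On these data alone, the step from 2,4-dichlorophenyl to cyclohexylcarbonyl changes the ring and adds a carbonyl in one move, so the share of each remains open. A cyclohexyl ring attached directly without the carbonyl, an open hexyl chain in place of the ring, or an amine on the ring would each leave open how much of this end can change.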